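A few compounds are considered here, and "the series" means these few. Any claim that something is new, unique, unknown or untested is made for them only; others in the source may bear on it.

Measured in a functional assay for inhibition, with Homo sapiens as the target; a higher number here means a weaker inhibitor, a lower number a stronger inhibitor:
- compound 1 `Cc1ccc2oc(NC(CC3CCCCC3)c3ccccn3)nc2c1`: 4 nM
- compound 2 `Cc1ccc2oc(N[C@@H](CC3CCCCC3)c3ccccn3)nc2c1`: 1 nM

Compound 2 holds the lower number of the two, and its gap to compound 1 lies beyond the scatter. Compound 3 `Cc1ccc2oc(N[C@H](CC3CCCCC3)c3ccccn3)nc2c1` has the same atoms and bonds as compound 2 and differs only at one centre: the two compounds have the same atoms and bonds and differ only in configuration as drawn: 1 of 1 stereo elements differ; a stereocentre at a saturated chain carbon is drawn S in compound 2 and R in compound 3. Within the data shown here, one measured step bears on this change: a 4.0-fold lower number from compound 1 to compound 2 (0.60 log units; beyond the scatter). This modest step comes with the fact that one of compounds 1 and 2 is drawn with a defined configuration and the other without, at the place where they differ. The data do not say whether compound 1 is a mixture of both forms. If it is, the lower number of compound 2 at 1 nM would suggest that the R form contributes less, although the size of that difference cannot be read directly from this step. A clear rise is therefore expected in this assay, with an estimated 30-fold higher number from compound 2 to compound 3 (1.48 log units; beyond the scatter). The estimated value for compound 3 is 30 nM, expected within 6 nM to 200 nM.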

Compound 3, half-maximal inhibitory concentration: 40 nM
Compound 3: middle estimate off by 1.3-fold (0.12 log units), on the low side, and the stated range covers the measured number.
By their numbers in this assay, from the lowest: compound 2; then compound 1; then compound 3.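

In this assay, the step of a 40-fold higher number from compound 2 to compound 3 (1.60 log units; beyond the scatter) is the first to isolate the configuration at this saturated chain carbon, with nothing else in the structure changed: the fact that compounds 2 and 3 differ only in the configuration as drawn

The drawing without a configuration falls between the two defined forms, with a 10-fold higher number from compound 1 to compound 3 (1.00 log units; beyond the scatter) on one side and a 4.0-fold lower number from compound 1 to compound 2 (0.60 log units; beyond the scatter) on the other: the fact that one of compounds 1 and 3 is drawn with a defined configuration and the other without, at the place where they differ

At this centre, then, the S drawing gives the lower number and the R drawing the higher, and the size of that gap is now measured rather than inferred.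

The data still do not say whether compound 1 is a mixture of both forms. Also open, from the compounds shown here alone, is whether the gap between S and R would persist if an amine or a longer chain stood at this centre in place of the present groups.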